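Thiosemicarbazone aryl replacement: chlorophenyl to furan-2-yl

The compounds below may be only part of what the source reports. "The series", "measured", "known", "first", "only" and "open" are said of these compounds alone.

Compound 2 `CC1=CC[C@H](C(C)(C)NC(=S)N/N=C/c2ccc(Cl)cc2)CC1` is the reference point. For the measured compounds named here, in a functional assay on MCF7 cells (Homo sapiens) for inhibition, read by sulforhodamine B assay, with a stated time of 48 h (a higher number here means a weaker inhibitor of growth, a lower number a stronger inhibitor of growth), compound 2 gives 18300 nM, the only measured number. Compound 1 `CC1=CC[C@H](C(C)(C)NC(=S)N/N=C/c2ccc(O)cc2)CC1` returns only a limit: in this assay compound 1 gives > 100000 nM, which is the limit of the assay and not a number (the limit of > 100000 nM in this assay, at which 1 of the 2 values shown sits). The step of an at least 5.4-fold lower number from compound 1 to compound 2 (0.73 log units; beyond the scatter) shows that the group on the aromatic ring moves the number by at least a modest amount in this direction.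

Compound 3 `CC1=CC[C@H](C(C)(C)NC(=S)N/N=C/c2ccco2)CC1` differs from compound 2 by furan-2-yl in place of 4-chlorophenyl on a carbon with a double bond to nitrogen. Going by the values given here, no measured step bears directly on this exchange, since the only step swaps a group on the ring rather than the ring itself. The one step shown, from compound 1 to compound 2, indicates that this part of the molecule matters, so a change beyond the scatter is plausible in either direction, with a higher number on balance expected once the 4-chlorophenyl is lost. Compound 3 is therefore estimated at 40000 nM, with a range of 10000 nM to 150000 nM, an expected step of a 2.2-fold higher number from compound 2 to compound 3 (0.34 log units; beyond the scatter).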

Compound 3, concentration for 50% growth inhibition: 9300 nM
Beside the measured number, compound 3's estimate is 4.3-fold (0.63 log units) above it, outside the stated range (below it).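

In this assay, furan-2-yl in place of 4-chlorophenyl on a carbon with a double bond to nitrogen gives a 2.0-fold lower number from compound 2 to compound 3 (0.29 log units; within the scatter), so at this place the two rings cannot be told apart, and neither the six-membered aromatic ring of carbon only nor the chlorine is required for a measurable number. Furan-2-yl in place of 4-hydroxyphenyl gives an at least 10-fold lower number from compound 1 to compound 3 (1.03 log units; beyond the scatter), which, taken with an at least 5.4-fold lower number from compound 1 to compound 2 (0.73 log units; beyond the scatter), sets the 4-hydroxyphenyl of compound 1 apart from both other rings, and the series now reads as one poor group rather than one favourable group. Compound 1 stands at a limit and not a number, so the true size of both steps stays unknown: the limit of > 100000 nM in this assay, at which 1 of the 3 values shown sits.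

Going by these compounds, whether the gap belongs to the hydroxy group itself remains open, and a 4-methoxyphenyl or 4-aminophenyl at this place would address that. On these data alone, all three compounds keep the same shared core and thiocarbonyl, so the outcome of a carbonyl in its place, or of a pyridine ring in place of furan-2-yl, also remains open.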